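The source may hold more compounds than are shown below. What is called first, only, known or untested is meant among the compounds shown, and "the series" means these compounds.

Three compounds have been measured in an assay on HEK293 cells for binding affinity to 5-hydroxytryptamine receptor 7 (Homo sapiens), read by radioligand binding, tested at 1 uM; a lower number here means less inhibition, a higher number more inhibition at the concentration tested (going by the name of the read-out):

Compound 1 `CC1CN(CCn2ccc3ccc(Br)cc32)CC(C)N1` gives 26%.
Compound 2 `CN1CCCN(CCn2ccc3cccc(Br)c32)CC1` gives 18%.
Compound 3 `CN1CCCN(CCn2ccc3ccc(Cl)cc32)CC1` gives 85%.

Among these three, compound 3 stands highest. Compound 1 lies well below it, and compound 2 lower still; both gaps are beyond the usual scatter. Compound 4 `CN1CCCN(CCn2ccc3ccc(OCc4ccccc4)cc32)CC1` has not yet been measured. It differs from compound 3 in one place: benzyloxy in place of chloro on an aromatic carbon. Among the compounds with values here, no measured pair shows this particular change, so its effect is not known from the data. The group entering is much larger than the one leaving, and a noticeable change in this assay seems more likely than none, with the direction uncertain. Compound 4 is expected to give 60%, within a range from 25% to 90%. The expected step is a number 25 percentage points lower from compound 3 to compound 4 (beyond the scatter), a fall beyond the scatter.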

Compound 4, a percentage reported as inhibition, at one concentration (the size of the read-out at that concentration, not a potency): 28%
For compound 4 the middle estimate is 32 percentage points above the measured one; the measured number falls inside the stated range.
By their numbers in this assay, from the lowest: compounds 2, 1 and 4 (each within the scatter of the next); then compound 3.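

In this assay, benzyloxy in place of chloro on this aromatic carbon, with the rest of the structure unchanged, gives a number 57 percentage points lower from compound 3 to compound 4 (beyond the scatter). The position is therefore not indifferent to what it carries, and this one exchange is enough to lose much of the inhibition. Nothing measured here gives a reason for the fall.

Still open, as far as these compounds go, is whether methoxy, which keeps the oxygen without the added ring, would hold the inhibition or lose it. Fluoro or bromo at this position would show how much the halogen itself matters.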